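Trimming the aryl ether on a triazole-sulfonamide

The compounds below may be only part of what the source reports. "The series", "measured", "known", "first", "only" and "open" are said of these compounds alone.

In a functional assay on A549 cells (Homo sapiens) for cytotoxicity, read by MTT assay, with a stated time of 48 h (a lower number here means a stronger inhibitor, a higher number a weaker inhibitor), compound 1 `COC(=O)c1ccccc1OCc1cn(-c2ccc(S(=O)(=O)N3CCc4ccccc4C3)cc2)nn1` gives 570 nM. Compound 2 `COc1cc2c(cc1OC)CN(S(=O)(=O)c1ccc(-n3cc(COc4ccccc4C)nn3)cc1)CC2` gives 27200 nM in this assay, the higher of the two numbers, and the gap to compound 1 lies beyond the scatter. Compound 3 `COc1cc2c(cc1OC)CN(S(=O)(=O)c1ccc(-n3cc(CO)nn3)cc1)CC2` differs from compound 2 by hydrogen in place of 2-methylphenyl on an oxygen on a saturated carbon. For the measured compounds named here, no such step has been measured here, so the direction is open; a weak compound losing a whole ring is expected to stay weak or drift higher. The step is estimated at a 1.8-fold higher number from compound 2 to compound 3 (0.26 log units; within the scatter). Compound 3 is therefore expected to give about 50000 nM, between 15000 nM and 150000 nM.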

Compound 3, half-maximal inhibitory concentration: 41000 nM
For compound 3 the middle estimate is 1.2-fold (0.09 log units) above the measured one; low and high end bracket the measured number.
By their numbers in this assay, from the lowest: compound 1; then compounds 2 and 3 (each within the scatter of the next).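

In this assay, the change from 2-methylphenoxy to hydroxy reads as a 1.5-fold higher number from compound 2 to compound 3 (0.18 log units; within the scatter), so on this core the whole 2-methylphenyl ring on the oxygen can be replaced by hydrogen without a difference the assay can resolve. For the compounds shown here, the compounds therefore give this position no measurable link to the number so far. Nothing available here explains this result. On these data alone, whether an amine, a carboxylic acid or a longer chain in this place would give a clearly different number remains open, as does whether the same change would read alike on the core of compound 1.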